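Methoxy in place of methyl, seen twice in one set

The source may hold more compounds than are shown below. What is called first, only, known or untested is meant among the compounds shown, and "the series" means these compounds.

The four compounds share two cores. Compound 1 `Cc1ccc(C(=O)N/N=C/c2cc(I)cc(I)c2O)cc1` and compound 2 `COc1ccc(C(=O)N/N=C/c2cc(I)cc(I)c2O)cc1` are built on the first, compound 3 `Cc1ccc(C(=O)NNC(=O)c2cc(I)cc(I)c2O)cc1` and compound 4 `COc1ccc(C(=O)NNC(=O)c2cc(I)cc(I)c2O)cc1` on the second; the difference between the two cores is not broken down here. All were or are to be tested in a functional assay on HepG2 cells (Homo sapiens) for cytotoxicity, with a stated time of 24 h; a lower number here means a stronger inhibitor, a higher number a weaker inhibitor.

In this assay compound 1 reaches only a limit of the assay, > 25000 nM. In this assay compound 2 gives 45200 nM. In this assay compound 3 gives 86400 nM, which lies within the usual scatter of the value for compound 2, so no order between those two can be drawn.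

Within the first core the change is methoxy in place of methyl on an aromatic carbon. The step it made, a step that the limit leaves unreadable from compound 1 to compound 2, cannot be sized, because the limit of > 25000 nM in this assay, at which 1 of the 3 values shown sits, hides where compound 1 truly sits. Within the second core the same change, (methoxy in place of methyl on an aromatic carbon), is made from compound 3 to compound 4.

Within the data shown here, with the only earlier instance of this change unreadable, nothing in the data argues for a sizeable move in either direction, and the step from compound 3 to compound 4 is expected to be small, a 1.1-fold lower number from compound 3 to compound 4 (0.03 log units; within the scatter). Compound 4 is therefore expected to give about 80000 nM in this assay, most likely between 35000 nM and 160000 nM.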

Compound 4, half-maximal inhibitory concentration: 132000 nM
Compound 4: the middle estimate sits 1.7-fold (0.22 log units) below what was measured; measured number inside the range.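

In this assay, methoxy in place of methyl on an aromatic carbon, para to a large group, gives a 1.5-fold higher number from compound 3 to compound 4 (0.18 log units; within the scatter). This step lies within the usual scatter, so in the second core the change has no effect that can be told apart from repeat variation, and compound 3 and compound 4 cannot be put in order. Whether the change behaves alike in the two cores stays unsettled, for the step within the first core cannot be read and compound 1 stands at a limit of the assay: the limit of > 25000 nM in this assay, at which 1 of the 4 values shown sits.

The series thus offers one readable instance of this change and no comparison between cores, and a single pair within the scatter supports no rule for the change in any other compound.

The compounds shown carry only methyl or methoxy at this place on the ring, so what an amine, a carboxylic acid or a longer chain such as butoxy would do there remains open. Also open, as far as these compounds go, is whether the reading for this change in the second core would hold with chlorine in place of the iodine atoms on the other ring.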